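The compounds below may be only part of what the source reports. "The series", "measured", "known", "first", "only" and "open" are said of these compounds alone.

Measured compounds:
compound 1, `CC(O)(CS(=O)(=O)c1ccc(OC(F)(F)F)cc1)C(=O)Nc1ccc(S(F)(F)(F)(F)F)cc1`, gives 95800 nM
compound 2, `CC(O)(CS(=O)(=O)c1cccc(OC(F)(F)F)c1)C(=O)Nc1ccc(S(F)(F)(F)(F)F)cc1`, gives 23700 nM
compound 3, `CC(O)(CS(=O)(=O)c1ccc(OC(F)(F)F)cc1)C(=O)Nc1cccc(S(F)(F)(F)(F)F)c1`, gives 15100 nM

All three were tested in a functional assay on VCaP cells (Homo sapiens) for antiproliferative activity, read by propidium iodide staining, with a stated time of 96 h; a lower number here means a stronger inhibitor, a higher number a weaker inhibitor. Compound 1 and compound 2 share one core and differ in a single place: 3-(trifluoromethoxy)phenyl in place of 4-(trifluoromethoxy)phenyl on a sulfonyl sulfur. That change produced a 4.0-fold lower number from compound 1 to compound 2 (0.61 log units; beyond the scatter). Compound 3 rests on a core of its own; how that core differs from the core of compound 1 is not broken down here. The values of compound 3 and compound 2 lie within the usual scatter of each other, while compound 1 gives a higher number than both.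

Compound 4, `CC(O)(CS(=O)(=O)c1cccc(OC(F)(F)F)c1)C(=O)Nc1cccc(S(F)(F)(F)(F)F)c1`, has not yet been measured. It relates to compound 3 just as compound 2 relates to compound 1: 3-(trifluoromethoxy)phenyl in place of 4-(trifluoromethoxy)phenyl on a sulfonyl sulfur. The surroundings of the changed group are the same in both pairs, so this is the same change made on a second core. Because the first instance gave a 4.0-fold lower number from compound 1 to compound 2 (0.61 log units; beyond the scatter), a step in the same direction is expected here, though a single earlier example is a thin base and the step may well come out smaller. The expected step is a 3.0-fold lower number from compound 3 to compound 4 (0.48 log units; beyond the scatter). Compound 4 is therefore estimated at 5000 nM, with a likely range from 1500 nM to 15000 nM.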

Compound 4, half-maximal inhibitory concentration: 20200 nM
For compound 4 the middle estimate is 4.0-fold (0.61 log units) below the measured one, outside the stated range (above it).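

On the second core, 3-(trifluoromethoxy)phenyl in place of 4-(trifluoromethoxy)phenyl on the sulfonyl sulfur gave a 1.3-fold higher number from compound 3 to compound 4 (0.13 log units; within the scatter) in this assay, so this swap makes no clear difference there. The lower number seen on the first core did not carry over, and the two outcomes differ by more than ordinary measurement noise: the same change on two cores in this assay, a 4.0-fold lower number (0.61 log units; beyond the scatter) from compound 1 to compound 2 and a 1.3-fold higher number (0.13 log units; within the scatter) from compound 3 to compound 4, 5.4-fold (0.73 log units) apart, beyond the scatter of two such steps

So in these two pairs, the result of the change depends on the core it is made on, and a step seen on one core was not a safe guide to the other; the data do not show why this happens, and two cores are too few for a rule covering the whole series.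

The compounds shown leave open how activity responds when the trifluoromethoxy group gives way to another group, such as a nitrile or a carboxylic acid. They also leave open how the same swap would behave on a third core, for example one carrying trifluoromethyl in place of the pentafluorosulfanyl group.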